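This account rests on a few compounds, and the source may have more. Where it says the series, first, only, none or still open, it means among the compounds named here.

Measured so far in a functional assay on MGC-803 cells (Homo sapiens) for antiproliferative activity, read by MTT assay, with a stated time of 72 h; on this read-out higher numbers stand for weaker inhibition and lower numbers for stronger inhibition:
compound 1 `COc1ccc(-c2nc(CNc3ccc(C(=O)NO)cc3)n(-c3ccccc3)n2)cc1` — > 20000 nM.
compound 2 `Cc1cccc(-n2nc(-c3ccccc3)nc2CNc2ccc(C(=O)NO)cc2)c1` — 13200 nM.
compound 3 `O=C(NO)c1ccc(NCc2nc(-c3ccccc3)nn2-c2ccc(F)cc2)cc1` — 10500 nM.

Compound 1 gives > 20000 nM, which is a limit of the assay, not a number; compound 1 sits at the limit of > 20000 nM in this assay, at which 1 of the 3 values shown sits. Compound 2 and compound 3 are within the scatter of each other, as a 1.3-fold lower number from compound 2 to compound 3 (0.10 log units; within the scatter) shows.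

Compound 4 `Cc1ccc(-c2nc(CNc3ccc(C(=O)NO)cc3)n(-c3ccccc3)n2)s1` differs from compound 1 by 5-methylthiophen-2-yl in place of 4-methoxyphenyl on an aromatic carbon. Within the data shown here, no measured step touches this position; the single measured step, a 1.3-fold lower number from compound 2 to compound 3 (0.10 log units; within the scatter), concerns the substituent on an aromatic nitrogen and gives no guide here. With compound 1 known only as a limit, the direction of any step is open, and a value in the weak range of compound 2 and compound 3 is the working assumption. Compound 4 is thus expected near 15000 nM, between 5000 nM and 40000 nM. The expected step of an at least 1.3-fold lower number from compound 1 to compound 4 (0.12 log units; that floor lies within the scatter) cannot be read against a limit.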

Compound 4, half-maximal inhibitory concentration: 8450 nM
Compound 4: middle estimate off by 1.8-fold (0.25 log units), on the high side; the range from low to high includes it.
By their numbers in this assay, from the lowest: compounds 4, 3 and 2 (each within the scatter of the next). At a limit, above all of these: compound 1.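

In this assay, the carbon position of the shared core responds to a change of group: 5-methylthiophen-2-yl in place of 4-methoxyphenyl gives an at least 2.3-fold lower number from compound 1 to compound 4 (0.37 log units; beyond the scatter). This is the only step shown at this position, and it lies beyond the scatter. The value of compound 1 is a limit of the assay, not a number, and the size of the step is only a floor: the limit of > 20000 nM in this assay, at which 1 of the 4 values shown sits.

The ring and its substituent change together here, and the compounds shown do not separate the two. On these data alone, how an amine or a carboxylic acid at this position would read remains open.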